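A few compounds are considered here, and "the series" means these few. Any claim that something is new, unique, unknown or untested is made for them only; others in the source may bear on it.

Of the compounds shown here, three built on one shared core have been measured in an assay on membranes from liver for displacement of a labelled ligand from Sigma non-opioid intracellular receptor 1 (Rattus norvegicus); on this read-out higher numbers stand for weaker inhibition and lower numbers for stronger inhibition. Compound 1 `O=c1oc2ccccc2n1CC1CCN(Cc2ccccc2)CC1` gives 3.6 nM. Compound 2 `O=c1oc2ccccc2n1CC1CCN(Cc2ccc(Cl)cc2)CC1` gives 0.1 nM. Compound 3 `O=c1oc2ccccc2n1CC1CCN(Cc2ccc(Cl)cc2Cl)CC1` gives 258 nM, the highest of the three numbers; the nearest to it is compound 1, separated by a 72-fold higher number from compound 1 to compound 3 (1.86 log units; beyond the scatter), and the furthest is compound 2, separated by a 2600-fold higher number from compound 2 to compound 3 (3.41 log units; beyond the scatter). A fourth compound, compound 4 `O=c1oc2ccccc2n1CC1CCN(Cc2ccccc2F)CC1`, has not yet been measured. It differs from compound 3 in a single place: 2-fluorophenyl in place of 2,4-dichlorophenyl on a saturated chain carbon bound to an amine nitrogen in a ring.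

Among the compounds with values here, two measured steps bear on this change. The step of a 36-fold lower number from compound 1 to compound 2 (1.56 log units; beyond the scatter) was a large fall, and the chloro it introduced is one of the two that leave here, so that part of the change would on its own be expected to push the number upward. The step of a 2600-fold higher number from compound 2 to compound 3 (3.41 log units; beyond the scatter) was a far larger rise, and the chloro it introduced also leaves here, which weighs more heavily in the opposite direction. Within the data shown here, the fluorine that enters has no measured counterpart among the three compounds, so its own contribution is unknown. Taken together, the step of a 32-fold lower number from compound 3 to compound 4 (1.51 log units; beyond the scatter) is expected to be large and downward. Compound 4 is therefore estimated at 8 nM, within a range from 1.5 nM to 50 nM.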

Compound 4, inhibition constant: 23 nM
Estimate against measurement, compound 4: 2.9-fold (0.46 log units) below, within the range that was stated.
By their numbers in this assay, from the lowest: compound 2; then compound 1; then compound 4; then compound 3.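

In this assay, within the data shown here, the step of a 6.4-fold higher number from compound 1 to compound 4 (0.81 log units; beyond the scatter) is the first reading of a halogen other than chloro on the phenyl at this place, and it shows that a single halogen there need not lower the number as the chloro of compound 2 did. The step of a 230-fold higher number from compound 2 to compound 4 (2.36 log units; beyond the scatter) makes this sharper: with 2-fluorophenyl in place of 4-chlorophenyl, most of that earlier gain is gone, so the effect at this place is not shared by every halogenated phenyl among these compounds. The step of an 11-fold lower number from compound 3 to compound 4 (1.05 log units; beyond the scatter) shows that the very high number of the 2,4-dichlorophenyl is not a general cost of a substituent on the phenyl at the 2-position named in these groups, though no measurement shown here explains any of these differences.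

Whether the gap between the 4-chlorophenyl and the 2-fluorophenyl follows the halogen itself or where it sits on the phenyl stays open, as the two differ at once and the compounds shown do not separate them. Also open, from the compounds shown here alone, is what a group other than a halogen, such as methoxy or an amine, would give on the phenyl.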